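This account rests on a few compounds, and the source may have more. Where it says the series, first, only, none or still open, it means among the compounds named here.

Measured compounds:
- compound 1, `O=C(NCc1ccc(NC(=O)c2cccc(F)c2N2CCCC2)cc1)OCc1cccnc1`, 2020 nM
- compound 2, `O=C(NCc1ccc(NC(=O)c2cc(Br)ccc2N2CCCC2)cc1)OCc1cccnc1`, 640 nM
- compound 3, `Cc1cccc(C(=O)Nc2ccc(CNC(=O)OCc3cccnc3)cc2)c1N1CCCC1`, 1030 nM

All three share one core and differ only in the substituent on the aromatic ring that carries the pyrrolidin-1-yl group. In a functional assay on HGC-27 cells (Homo sapiens) for inhibition, read by MTT assay, with a stated time of 72 h (on this read-out higher numbers stand for weaker inhibition and lower numbers for stronger inhibition), compound 2 gives the lowest number of the three. Its gap to compound 3 is within the scatter, so the two cannot be ordered; its gap to compound 1 is beyond the scatter. Among the compounds with values here, the only one-place step among the measured compounds is a 2.0-fold lower number from compound 1 to compound 3 (0.29 log units; within the scatter), which swaps two small groups and stays within the scatter.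

Compound 4, `O=C(NCc1ccc(NC(=O)c2cc(C(F)(F)F)ccc2N2CCCC2)cc1)OCc1cccnc1`, is not yet measured. It differs from compound 2 by trifluoromethyl in place of bromo on an aromatic carbon. Within the data shown here, no measured step swaps bromo for trifluoromethyl, and the one step that does exist concerns other groups; it bears on compound 4 only by showing that a small change of substituent on this ring moved the number little. For this assay no step beyond the scatter is therefore expected, and compound 4 is estimated at 800 nM, with a range from 350 nM to 1800 nM. That estimate means an expected step of a 1.3-fold higher number from compound 2 to compound 4 (0.10 log units; within the scatter).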

Compound 4, half-maximal inhibitory concentration: 790 nM
The estimate for compound 4 lay 1.0-fold (0.01 log units) above the measured number; the range from low to high includes it.
By their numbers in this assay, from the lowest: compounds 2, 4, 3 and 1 (each within the scatter of the next, the first and the last beyond it).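

At the aromatic carbon para to the pyrrolidin-1-yl group, trifluoromethyl in place of bromo gives in this assay a 1.2-fold higher number from compound 2 to compound 4 (0.09 log units; within the scatter) and so stays within the scatter, even though one heavy atom is replaced by four heavy atoms, with no hydrogen-bond donor or acceptor on either side. This is the first one-place step shown at this position, since the earlier step, fluoro to methyl between compound 1 and compound 3, lies on a different aromatic carbon of the same ring, so the two results cannot be merged into one rule for the ring. At this position, compound 2 and compound 4 cannot be ordered, and nothing available gives a reason for that outcome, which stands as an observation on two substituents only.

Still open, as far as these compounds go, is whether the number at this carbon would stay in the same range with an amine, a carboxylic acid or a longer chain such as n-butyl in place of bromo, or with plain hydrogen there. Equally open, from the compounds shown here alone, is whether bromo and trifluoromethyl would also stay within the scatter of each other on the carbon that carries fluoro in compound 1 and methyl in compound 3.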